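Moving the Methylpyrazole Attachment Point on Compound 1

This account rests on a few compounds, and the source may have more. Where it says the series, first, only, none or still open, it means among the compounds named here.

Among the measured compounds shown here, in an ADME assay on microsomes from liver (Homo sapiens) for metabolic stability, read by LC-MS, using NADPH, with stated times of 5 min and 30 min, tested at 1 uM (a higher number here means faster removal of the compound, a lower number slower removal), compound 1 (`Cn1cc(-c2cnc(NCc3c(F)ccc4c3CCO4)c3cn[nH]c(=O)c23)cn1`) gives 21 mL.min-1.g-1 and compound 2 (`O=C1c2ccccc2CN1c1cnc(NCc2c(F)ccc3c2CCO3)n2cnnc12`) gives 13 mL.min-1.g-1 as the only other measured number, and these two values lie within the scatter of each other. Compound 3 (`Cn1nccc1-c1cnc(NCc2c(F)ccc3c2CCO3)c2cn[nH]c(=O)c12`) keeps the core of compound 1 and has the same atoms, joined differently: 1-methyl-1H-pyrazol-5-yl stands in place of 1-methyl-1H-pyrazol-4-yl on an aromatic carbon (1-methyl-1H-pyrazol-5-yl in place of 1-methyl-1H-pyrazol-4-yl on an aromatic carbon). For the measured compounds named here, no measured pair shows what such a swap does in this assay and neither direction is favoured, so no shift beyond the scatter is expected. The estimated change is small (a 1.1-fold lower number from compound 1 to compound 3 (0.02 log units; within the scatter)). For compound 3 the expected value is 20 mL.min-1.g-1 with an estimated range around it (10 mL.min-1.g-1 to 40 mL.min-1.g-1).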

Compound 3, intrinsic clearance in microsomes: 14 mL.min-1.g-1
Compound 3: the middle estimate sits 1.4-fold (0.15 log units) above what was measured; measured number inside the range.
By their numbers in this assay, from the lowest: compounds 2, 3 and 1 (each within the scatter of the next).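

Among the compounds shown here, compound 3 provides the first measured step at this position: in this assay, 1-methyl-1H-pyrazol-5-yl in place of 1-methyl-1H-pyrazol-4-yl gives a 1.5-fold lower number from compound 1 to compound 3 (0.18 log units; within the scatter) and so shows that, on this core, joining the same atoms differently leaves the two numbers within the scatter of each other. Compound 1 and compound 2 differ in more than one place and could not show this. Nothing in the available data bears on what lies behind this result.

On these data alone, whether a different kind of group on this aromatic carbon, such as an amine, a carboxylic acid or a morpholine ring, would give a number beyond the scatter remains open. The compounds shown also leave open whether the same swap would read the same way on another core, such as that of compound 2.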